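The compounds below may be only part of what the source reports. "The series", "measured", "known", "first", "only" and "open" are said of these compounds alone.

Measured so far:
compound 1, `CC(C)(C)Cc1csc(N)c1C(=O)c1ccc(Cl)cc1`: 5%
compound 2, `CC(C)(C)Cc1c(-c2ccccc2)sc(N)c1C(=O)c1ccc(Cl)cc1`: 1%

In an assay on CHO cells for displacement of a labelled ligand from adenosine receptor A3 (Homo sapiens), read by scintillation counting, tested at 10 uM (on this read-out lower numbers stand for less inhibition and higher numbers for more inhibition at the one concentration tested (going by the name of the read-out)), compound 1 gives 5%, and compound 2 gives 1%. Within the data shown here, the one step between them, a number 4 percentage points lower from compound 1 to compound 2 (within the scatter), lies within the scatter, so the two numbers cannot be told apart; both compounds show close to no inhibition at the concentration tested. Compound 2 therefore stands on the same footing as compound 1, not clearly lower or higher.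

Compound 3, `CC(C)(C)Cc1c(-c2ccccc2)sc(N)c1C(=O)c1ccccc1Cl`, differs from compound 2 in one place: 2-chlorophenyl in place of 4-chlorophenyl on a carbonyl carbon. Among the measured compounds shown here, no measured step involves this change, so the only guide is that compound 2 itself sits at the bottom of the read-out scale, and the one change that has been measured on this core, the phenyl in place of hydrogen, left the number within the scatter. With that, the step of a number 2 percentage points higher from compound 2 to compound 3 (within the scatter) is expected to stay within the scatter, with no clear direction. Compound 3 is estimated at 3%, in a range from -6% to 13%.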

Compound 3, a percentage reported as inhibition, at one concentration (the size of the read-out at that concentration, not a potency): 1%
The estimate for compound 3 lay 2 percentage points above the measured number, and the stated range covers the measured number.
By their numbers in this assay, from the lowest: compounds 2, 3 and 1 (each within the scatter of the next).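

In this assay, among these compounds, 2-chlorophenyl in place of 4-chlorophenyl on the carbonyl carbon gives no change at the digits printed from compound 2 to compound 3 (within the scatter) and so adds a first reading at this place, since the earlier step concerned only phenyl in place of hydrogen on an aromatic carbon. Compounds 2 and 3 hold the same atoms joined differently, and this rearrangement leaves their numbers indistinguishable, with both close to no inhibition at the one concentration tested; with so little inhibition to compare, the result says little about how this swap would behave on a compound with clear inhibition. Nothing available bears on why the two numbers match.

The compounds shown leave open whether a different group on the carbonyl carbon, such as a plain phenyl or a methoxyphenyl, would give a number clear of the scatter. They also leave open whether an amine or a carboxylic acid on the phenyl of the shared core would produce real inhibition, against which the choice between the two chlorophenyl groups could then be judged.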